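Replacing a Vinyl Group with an Oxazolyl Ring

The compounds below may be only part of what the source reports. "The series", "measured", "known", "first", "only" and "open" are said of these compounds alone.

Compound 2 `C=Cc1cccc(C(=O)N2CCCC(C(=O)Nc3ccc(Cl)cc3)C2)c1` gives 0% in an ADME assay on PC-3 cells (Homo sapiens) for cytotoxicity, read by WST assay, tested at 100 uM (a lower number here means less inhibition, a higher number more inhibition at the concentration tested (going by the name of the read-out)), while compound 1 `O=C(Nc1ccc(Cl)cc1)C1CCCN(C(=O)c2cccc(-c3cccs3)c2)C1` gives 4% there, and the step of a number 4 percentage points lower from compound 1 to compound 2 (within the scatter) lies within the scatter. Compound 2 thus has the lowest of the two numbers shown, but its gap to compound 1 is within the scatter, so no order between them can be read. Compound 3 `O=C(Nc1ccc(Cl)cc1)C1CCCN(C(=O)c2cccc(-c3cnco3)c2)C1` differs from compound 2 by 1,3-oxazol-5-yl in place of vinyl on an aromatic carbon. Among the compounds with values here, the only measured step that bears on this change is a number 4 percentage points lower from compound 1 to compound 2 (within the scatter), which exchanged a five-membered aromatic ring for vinyl on the same aromatic carbon without moving the number beyond the scatter. Because a number 4 percentage points lower from compound 1 to compound 2 (within the scatter) stayed within the scatter, the reverse exchange of vinyl for another five-membered aromatic ring is expected to give no step beyond the scatter, a number 3 percentage points higher from compound 2 to compound 3 (within the scatter). Compound 3 is therefore expected to show 3%, with a range from -8% to 15%.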

Compound 3, a percentage reported as inhibition, at one concentration (the size of the read-out at that concentration, not a potency): 0%
For compound 3 the middle estimate is 3 percentage points above the measured one; measured number inside the range.
By their numbers in this assay, from the lowest: compounds 2, 3 and 1 (each within the scatter of the next).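

The exchange of vinyl for 1,3-oxazol-5-yl gives no change at the digits printed from compound 2 to compound 3 (within the scatter) in this assay and the exchange of thiophen-2-yl for the same ring gives a number 4 percentage points lower from compound 1 to compound 3 (within the scatter) at the same place. On this aromatic carbon, meta to a large group, three different groups now stand within the scatter of one another. Within the data shown here, that set now includes a ring with two hetero atoms that carries hydrogen-bond acceptors, which neither vinyl nor thiophen-2-yl brought to this position in the earlier compounds.

The compounds shown leave open whether an amine, a carboxylic acid or a longer alkyl chain at this place would give a step beyond the scatter. No measurement offered here explains why these three groups give such closely matching numbers.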